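This account rests on a few compounds, and the source may have more. Where it says the series, first, only, none or still open, it means among the compounds named here.

Measured so far:
compound 1, `O=C1NC(=O)/C(=C/c2ccc(OCc3csc(-c4ccccc4)n3)cc2)S1`, 20.4%
compound 2, `O=C1NC(=O)/C(=C/c2ccc(OCCSc3nnc(-c4ccccc4)[nH]3)cc2)S1`, 10.6%

Both numbers come from a functional assay on the whole organism (plasma, strain Wistar) with Rattus norvegicus as the target, with a stated time of 15 days, at a dose of 10 mg/kg by the oral route; a higher number here means a stronger effect of the compound at the dose given, a lower number a weaker effect. Among the measured compounds shown here, compound 2 and compound 1 are the only two compounds with a number, and the number of compound 1 lies within the usual scatter of the number of compound 2, so the two cannot be told apart on this reading. Compound 2 also carries a different linker and a different five-membered ring from compound 1, so no single change separates them.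

Compound 3, `O=C1NC(=O)/C(=C/c2ccc(OCCSc3nnc(Cc4ccccc4)[nH]3)cc2)S1`, differs from compound 2 in one place: benzyl in place of phenyl on an aromatic carbon. For the measured compounds named here, no step of this kind has been measured, so the direction is open. For compound 3 the expectation is a step from compound 2 of a number 1.4 percentage points higher from compound 2 to compound 3 (within the scatter), which is no step beyond the scatter. Compound 3 is therefore estimated at 12%, within a range from 0% to 30%.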

Compound 3, a percentage reported as activity, at one dose (the size of the read-out at that dose, not a potency): 19.4%
Estimate against measurement, compound 3: 7.4 percentage points below, within the range that was stated.
By their numbers in this assay, from the lowest: compounds 2, 3 and 1 (each within the scatter of the next).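

Among the compounds shown here, compound 2 and compound 3 give the first comparison that turns on a single place, the aromatic carbon of the five-membered ring with 3 nitrogen. In this assay, benzyl in place of phenyl at this carbon comes with a number 8.8 percentage points higher from compound 2 to compound 3 (within the scatter), so this reading does not separate the two groups, and the position accepts either one without a clear difference in effect at this dose. The compounds shown offer no measurement that could explain this reading.

Going by these compounds, it remains open whether a longer chain such as phenylethyl, or a carboxylic acid, at this carbon would stand clearly apart from phenyl and benzyl. Also open, on these data alone, is whether the same swap would read alike on the different linker and five-membered ring of compound 1.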